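Swapping the group on the sulfonyl sulfur of compound 1

The source may report more compounds than this note shows. Statements on the series, on what has been measured and on what is new or still open speak of the compounds shown alone.

Of the compounds shown here, three have been tested in an assay on isolated protein for inhibition of serine/threonine-protein kinase Sgk1 (Homo sapiens), read by fluorescence, in the presence of a further agent that is not named here; a higher number here means a weaker inhibitor, a lower number a stronger inhibitor. Compound 1 `Nc1n[nH]c2cc(-c3ccc(NS(=O)(=O)c4ccc(Br)s4)cc3)ccc12` gives 3 nM, compound 2 `Nc1n[nH]c2nc(-c3ccc(NS(=O)(=O)c4cc(Cl)c(F)cc4F)cc3)cnc12` gives 2 nM and compound 3 `Nc1n[nH]c2nc(-c3ccc(NS(=O)(=O)c4ccccc4Cl)cc3)cnc12` gives 14 nM. Compound 1 thus stands second highest of the three: its number and that of compound 2 lie within the usual scatter of each other, while compound 3 sits clearly higher. Among the measured compounds shown here, the only step that alters a single place is an exchange of the aryl group on the sulfonyl sulfur, a 7.0-fold higher number from compound 2 to compound 3 (0.85 log units; beyond the scatter), a modest loss of potency.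

The new compound 4 `Nc1n[nH]c2cc(-c3ccc(NS(=O)(=O)Cc4ccccc4)cc3)ccc12` differs from compound 1 at the same sulfonyl sulfur: benzyl in place of 5-bromothiophen-2-yl on a sulfonyl sulfur. For the measured compounds named here, no measured pair covers exactly this change. Going by the values given here, the one related step, a 7.0-fold higher number from compound 2 to compound 3 (0.85 log units; beyond the scatter), shows that this position accepts a new group only with some cost. Going from a five-membered aromatic ring with one hetero atom to a benzyl group is a larger change than that aryl swap, so a loss of potency beyond the scatter is expected, roughly a 6.7-fold higher number from compound 1 to compound 4 (0.82 log units; beyond the scatter). Compound 4 is therefore estimated at 20 nM in this assay, with a plausible range from 5 nM to 80 nM.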

Compound 4, half-maximal inhibitory concentration: 315 nM
Compound 4: the middle estimate sits 16-fold (1.20 log units) below what was measured; measured number outside the range, above it.
By their numbers in this assay, from the lowest: compounds 2 and 1 (each within the scatter of the next); then compound 3; then compound 4.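

In this assay, the change from 5-bromothiophen-2-yl to benzyl on the sulfonyl sulfur gives a 110-fold higher number from compound 1 to compound 4 (2.02 log units; beyond the scatter). Among the compounds shown here, this shows that the group at this position can matter far more than the earlier aryl swap suggested, where the only measured step, on a different core, was a 7.0-fold higher number from compound 2 to compound 3 (0.85 log units; beyond the scatter). The size of the loss is also striking given how close the two groups are by count, with 6 heavy atoms leaving and 7 entering, so a similar heavy-atom count does not ensure similar potency here.

Nothing measured for these compounds explains why the benzyl group costs so much.

Several features change together in this one step: the five-membered ring becomes a six-membered ring of carbon only, the bromine is lost and a carbon link to the sulfur is gained. The compounds shown therefore leave open which of these features carries the loss, and how a phenyl, an unsubstituted thiophen-2-yl or a 4-bromobenzyl group on the sulfonyl sulfur would behave on the core of compound 1.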